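Adding a Second Methyl to the Amide Nitrogen

A few compounds are considered here, and "the series" means these few. Any claim that something is new, unique, unknown or untested is made for them only; others in the source may bear on it.

Measured so far:
compound 1 `CNC(=O)/C=C/c1ccncc1-c1ccc2ccccc2c1` — 8680 nM
compound 2 `CCOC(=O)/C=C/c1ccncc1-c1ccc2[nH]ccc2c1` — a limit only: > 10000 nM
compound 3 `Cn1ncc2cc(-c3cnccc3/C=C/C(=O)O)ccc21` — a limit only: > 10000 nM

All three were tested in a functional assay on MDA-MB-231 cells (Homo sapiens) for inhibition, read by sulforhodamine B assay, with a stated time of 72 h; on this read-out lower numbers stand for stronger inhibition of growth and higher numbers for weaker inhibition of growth. Compound 1 is the only one of them for which a number was obtained. For compound 2 the result is a limit of the assay, not a number. For compound 3 the result is likewise a limit, not a number. So compound 1 stands alone as the measured point, and the other two sit at the limit of > 10000 nM in this assay, at which 2 of the 3 values shown sit.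

The new compound is compound 4 `CN(C)C(=O)/C=C/c1ccncc1-c1ccc2ccccc2c1`. Compared with compound 1 it carries methyl in place of hydrogen on an amide-type nitrogen. The change is thus one methyl more on the amide-type nitrogen, with the rest of the molecule kept the same.

Within the data shown here, no pair of measured compounds differs in only one place, so there is no measured step to lean on. The expected step from compound 1 to compound 4 is a 1.0-fold higher number from compound 1 to compound 4 (0.02 log units; within the scatter), which is no larger than the scatter of repeated measurements. On that basis compound 4 is estimated at 9000 nM, with a range from 3000 nM to 25000 nM.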

Compound 4, concentration for 50% growth inhibition: 7990 nM
Estimate against measurement, compound 4: 1.1-fold (0.05 log units) above, within the range that was stated.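

In this assay, among these compounds, putting a second methyl on the amide nitrogen gives a 1.1-fold lower number from compound 1 to compound 4 (0.04 log units; within the scatter), the first step that can be read at this position. The amide hydrogen of compound 1 is therefore not needed to keep this level of growth inhibition, and the nitrogen accepts a methyl in its place without a readable shift. Compound 2 and compound 3 give no number to set against this, only a limit of the assay: the limit of > 10000 nM in this assay, at which 2 of the 4 values shown sit.

Going by these compounds, it remains open whether a longer chain on this nitrogen, such as butyl, or a chain ending in an amine, would give a different result. With only these two amides on the shared core, it is also unknown whether any group at this nitrogen can move the number beyond the scatter.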